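The source may hold more compounds than are shown below. What is called first, only, known or untested is meant among the compounds shown, and "the series" means these compounds.

Measured so far in an ADME assay on SW480 cells (Homo sapiens) for cytotoxicity, read by MTT assay, with a stated time of 72 h; on this read-out lower numbers stand for stronger inhibition and higher numbers for weaker inhibition:
- compound 1 `COc1ccc(NC(=O)c2cccc(/C=C3\CC(=O)N(c4ccccc4)C3=O)c2)c(C)c1`: > 100000 nM, a limit of the assay
- compound 2 `Cc1ccc(N2C(=O)C/C(=C\c3cccc(C(=O)Nc4ccc(Cl)cc4)c3)C2=O)cc1`: > 100000 nM, a limit of the assay
- compound 3 `CSc1cccc(NC(=O)c2cccc(/C=C3\CC(=O)N(c4ccccc4)C3=O)c2)c1`: 74300 nM

Among the compounds with values here, compound 3 holds the only number in this assay; the other two values are limits. Within the data shown here, the one measured step, an at least 1.3-fold lower number from compound 1 to compound 3 (0.12 log units; that floor lies within the scatter), stays within the scatter and rests on (the limit of > 100000 nM in this assay, at which 2 of the 3 values shown sit). Compound 4 `O=C(Nc1ccc(Cl)cc1)c1cccc(/C=C2\CC(=O)N(c3ccccc3)C2=O)c1` follows from compound 3 by the change (4-chlorophenyl in place of 3-(methylsulfanyl)phenyl on an amide-type nitrogen). Among the measured compounds shown here, compound 2 also carries 4-chlorophenyl on that nitrogen and sits at the limit, and no step links it to compound 4. Compound 4 is therefore expected to show no step beyond the scatter, a 1.3-fold higher number from compound 3 to compound 4 (0.13 log units; within the scatter), and is expected near 100000 nM, within 40000 nM to 300000 nM, quite possibly reported only as a limit.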

Compound 4, half-maximal inhibitory concentration: > 100000 nM
Compound 4 gave a limit, no number; the forecaster's own chance of this, stated with the estimate: 60%; the middle value lies on the limit itself.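

In this assay, 4-chlorophenyl in place of 3-(methylsulfanyl)phenyl on the amide-type nitrogen gives an at least 1.3-fold higher number from compound 3 to compound 4 (0.12 log units; that floor lies within the scatter), so no change at this position has yet been shown to go beyond the scatter. Compound 4 gives a limit and not a number, which leaves the reading of this position resting on compound 3 alone and on: the limit of > 100000 nM in this assay, at which 3 of the 4 values shown sit.
The steps to compound 4 from compound 1 and from compound 2 cannot be read, as both ends are limits.

Still open, on these data alone, is whether any group on this nitrogen lowers the number beyond the scatter. A phenyl ring carrying a dimethylamino group or a carboxylic acid would test this.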